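A Methyl on the Six-Membered Ring of a Dipropylxanthine

This account rests on a few compounds, and the source may have more. Where it says the series, first, only, none or still open, it means among the compounds named here.

Measured compounds:
compound 1 `CCCn1c(=O)n(CC)c(=O)c2[nH]cnc21`: 1400 nM
compound 2 `CCCn1c(=O)n(CC)c(=O)c2c1ncn2C`: 11800 nM
compound 3 `CCCn1cnc2c1c(=O)[nH]c(=O)n2CCC`: 18200 nM

All three were tested in an assay on membranes from brain for displacement of a labelled ligand from adenosine receptor A1 (Cavia porcellus); a higher number here means a weaker inhibitor, a lower number a stronger inhibitor. Compound 1 gives 1400 nM; compound 2 gives 11800 nM; compound 3 gives 18200 nM. The change methyl in place of hydrogen on an aromatic nitrogen produced an 8.4-fold higher number from compound 1 to compound 2 (0.93 log units; beyond the scatter). The difference between the cores of compound 1 and compound 3 is not broken down here.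

Compound 4 `CCCn1cnc2c1c(=O)n(C)c(=O)n2CCC` has not yet been measured. It arises from compound 3 by methyl in place of hydrogen on an aromatic nitrogen, the same kind of change as from compound 1 to compound 2, but at a different place: here the methyl sits on the six-membered aromatic ring with 2 nitrogen, ortho to two groups of 1 heavy atom each, rather than on the five-membered ring. Among the measured compounds shown here, with only one earlier step, at another place, the guide is weak. In this assay compound 4 is expected to show a 3.6-fold lower number from compound 3 to compound 4 (0.56 log units; beyond the scatter), giving an estimated 5000 nM, between 1500 nM and 16000 nM.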

Compound 4, inhibition constant: 9400 nM
For compound 4 the middle estimate is 1.9-fold (0.27 log units) below the measured one; the measured number falls inside the stated range.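

In this assay, methyl in place of hydrogen on an aromatic nitrogen of the six-membered ring gave a 1.9-fold lower number from compound 3 to compound 4 (0.29 log units; within the scatter) and so left no difference that can be told from the scatter on this core. The change did not carry over with the size of the earlier step, which stood on the five-membered ring of another core: the same change on two cores in this assay, an 8.4-fold higher number (0.93 log units; beyond the scatter) from compound 1 to compound 2 and a 1.9-fold lower number (0.29 log units; within the scatter) from compound 3 to compound 4, 16-fold (1.21 log units) apart, beyond the scatter of two such steps. Each core is seen with the methyl at one place only, so these two steps do not show whether the core or the place accounts for the gap.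

The compounds shown leave open how a longer chain or an amine on that same nitrogen would read in this assay. They also leave open whether a methyl on the six-membered ring of the core of compound 1 would behave as it does on the core of compound 3.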